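Aromatic in place of alkyl on the ring amine nitrogen

A few compounds are considered here, and "the series" means these few. Any claim that something is new, unique, unknown or untested is made for them only; others in the source may bear on it.

Among the measured compounds shown here, compound 3 `CCCCCCN1CCC(N2CC(c3ccnc4ccc(OC)cc34)OC2=O)CC1` gives 501 nM in an in vitro functional assay on RBL cells for antagonist activity at C-C chemokine receptor type 8 (Homo sapiens), read by FLIPR and calcium flux (on this read-out higher numbers stand for weaker inhibition and lower numbers for stronger inhibition), the only number among the three values shown. Compound 1 `O=C1OC(c2ccc3ccccc3n2)CN1C1CCN(Cc2cc3ccccc3[nH]2)CC1` gives only a limit, < 50200 nM, in this assay. Compound 2 `COc1ccc2nccc(C3CN(C4CCN(C)CC4)C(=O)O3)c2c1` likewise gives only a limit, < 50200 nM. The step that the limit leaves unreadable from compound 2 to compound 3 cannot be sized, since the limit of < 50200 nM in this assay, at which 2 of the 3 values shown sit, leaves it unreadable. Compound 4 `COc1ccc2nccc(C3CN(C4CCN(Cc5ccc(Cl)c(Cl)c5)CC4)C(=O)O3)c2c1` differs from compound 3 by 3,4-dichlorophenyl in place of pentyl on a saturated chain carbon bound to an amine nitrogen in a ring. No measured step covers this change, and the one step shown has no readable size, so the expectation rests on the change alone. Compound 4 is estimated at 200 nM in this assay, within 40 nM to 1000 nM. The step of a 2.5-fold lower number from compound 3 to compound 4 (0.40 log units; beyond the scatter) is expected to lean toward stronger inhibition, though not clearly beyond the scatter.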

Compound 4, half-maximal inhibitory concentration: 126 nM
For compound 4 the middle estimate is 1.6-fold (0.20 log units) above the measured one; low and high end bracket the measured number.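

In this assay, 3,4-dichlorophenyl in place of pentyl on a saturated chain carbon bound to an amine nitrogen in a ring gives a 4.0-fold lower number from compound 3 to compound 4 (0.60 log units; beyond the scatter), so an aromatic ring is tolerated in this place and compares favourably with the alkyl chain. Compound 2 gives a limit, and the steps from it cannot be read: the limit of < 50200 nM in this assay, at which 2 of the 4 values shown sit.

Whether the aromatic ring or the two chlorines account for this step stays open. Plain benzyl in the same place, without chlorine, would separate the two.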